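The source may hold more compounds than are shown below. What is called first, only, known or untested is meant among the compounds shown, and "the series" means these compounds.

Compound 1 `CC1=C(C(=O)C2CC2)C(c2ccoc2)NC(=O)N1` gives 16%
Compound 2 `CCC(C)OC(=O)C1=C(C)NC(=O)NC1c1ccoc1` gives 11%

Both numbers come from an assay on membranes from HeLa cells for displacement of a labelled ligand from adenosine receptor A3 (Homo sapiens), read by scintillation counting, with a stated time of 180 min, tested at 1 uM; a higher number here means more inhibition at the concentration tested (going by the name of the read-out), a lower number less inhibition. Compound 2 and compound 1 lie within the scatter of each other, so the two show the same low level of inhibition. Compound 3 `CC1=C(C(=O)OC2CCC2)C(c2ccoc2)NC(=O)N1` is not yet measured. Its change from compound 2 is cyclobutyl in place of sec-butyl on an oxygen next to a carbonyl group. For the measured compounds named here, the only measured step, a number 5 percentage points lower from compound 1 to compound 2 (within the scatter), swapped a group on a carbonyl carbon and stayed within the scatter; no measured step swaps one four-carbon group for another on an oxygen next to a carbonyl group. The step expected is therefore a number 2 percentage points higher from compound 2 to compound 3 (within the scatter), nothing beyond the scatter. Compound 3 is estimated at 13%, between 0% and 30%.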

Compound 3, a percentage reported as inhibition, at one concentration (the size of the read-out at that concentration, not a potency): 1%
The estimate for compound 3 lay 12 percentage points above the measured number, and the stated range covers the measured number.
By their numbers in this assay, from the lowest: compounds 3, 2 and 1 (each within the scatter of the next, the first and the last beyond it).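

In this assay, cyclobutyl in place of sec-butyl on an oxygen next to a carbonyl group gives a number 10 percentage points lower from compound 2 to compound 3 (within the scatter) and so does not set the ring apart from the open chain. Cyclobutyloxy in place of cyclopropyl on a carbonyl carbon gives a number 15 percentage points lower from compound 1 to compound 3 (beyond the scatter) and is the first step here to pass the scatter, though only modestly. Nothing available explains this difference. Still open, as far as these compounds go, is how a benzyl group or a longer chain such as hexyl on that oxygen would read, and whether an amine on the carbonyl carbon would raise the inhibition.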